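The compounds below may be only part of what the source reports. "The series", "measured", "known", "first", "only" and "open" are said of these compounds alone.

Measured in a physicochemical assay for solubility, read by nephelometry, in phosphate buffer, measured as kinetic solubility, with a stated time of 30 min, at pH 6.5; on this read-out lower numbers stand for lower solubility and higher numbers for higher solubility:
- Compound 1 `CCOC(=O)COc1ccc([C@H]2CC[C@]3(CC2)OOC2(O3)C3CC4CC(C3)CC2C4)cc1`: < 1.6 ug/mL
- Compound 2 `CC(C)(Oc1ccc([C@H]2CC[C@]3(CC2)OOC2(O3)C3CC4CC(C3)CC2C4)cc1)C(=O)O`: < 1.6 ug/mL

Compound 2 stands at < 1.6 ug/mL, which is a limit of the assay and not a number. Compound 1 also gives only a limit, so neither compound has a true reading. What the data offer is the limit of < 1.6 ug/mL in this assay, at which 2 of the 2 values shown sit.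

Compound 3 `O=C(O)CCCOc1ccc([C@H]2CC[C@]3(CC2)OOC2(O3)C3CC4CC(C3)CC2C4)cc1` has not yet been measured. It keeps the shared core of compound 2 but carries 3-carboxypropyl in place of 1-carboxy-1-methylethyl on an oxygen on an aromatic ring. The two compounds have the same atoms, joined differently.

Going by the values given here, the only measured change at this kind of place is a step that the two limits leave unreadable from compound 1 to compound 2. That step offers no size to carry over, so no step beyond the usual scatter is expected in this assay, in either direction. The assay may well report only a limit again.

The expected step is a number no lower from compound 2 to compound 3 (the limit leaves the size open), and this is only an estimate. For compound 3 the estimated value is 1.6 ug/mL, with an expected range from 0.8 ug/mL to 6 ug/mL.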

Compound 3, solubility: < 3.1 ug/mL
Compound 3 gave a limit, no number; the forecaster's own chance of this, stated with the estimate: 60%; the middle value does not contradict the limit.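

In this assay, going by these compounds alone, compound 1, compound 2 and compound 3 each give only a limit of the assay and not a number, so no step among them can be read. The compounds shown leave open where the true value of each lies, and whether 3-carboxypropyl and 1-carboxy-1-methylethyl on an oxygen on an aromatic ring differ at all in this assay.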